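Two indole amines and a methyl added to each

This account rests on a few compounds, and the source may have more. Where it says the series, first, only, none or still open, it means among the compounds named here.

Three compounds share the same inhibition read-out. Compound 1 `CC#CCN(C)Cc1cc2cc(O)ccc2n1C` and compound 2 `C#CCN(C)Cc1cc2cc(O)ccc2n1C` have a common core, while compound 3 `CCNCc1cn(Cc2ccccc2)c2ccccc12` is built on a different core; the difference between the two cores is not broken down here. In an assay on isolated protein for inhibition of Amine oxidase [flavin-containing] A (Rattus norvegicus) (on this read-out lower numbers stand for stronger inhibition and higher numbers for weaker inhibition), compound 2 gives 4 nM, compound 1 gives 5.7 nM, and compound 3 gives 262000 nM, which stands far away from both of the others.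

The measured pair shows one change: methyl in place of hydrogen on a triple-bonded carbon, and that step was a 1.4-fold higher number from compound 2 to compound 1 (0.15 log units; within the scatter). The unmeasured compound 4 `CC(C)NCc1cn(Cc2ccccc2)c2ccccc12` carries the same kind of change relative to compound 3, namely (methyl in place of hydrogen on a saturated chain carbon bound to an amine nitrogen and a saturated chain carbon). The surroundings are not the same, however: in compound 1 the methyl enters on a triple-bonded carbon whose other neighbour is a triple-bonded carbon, whereas in compound 4 it enters on a saturated chain carbon bound to an amine nitrogen and a saturated chain carbon.

Because the methyl added on the triple-bonded carbon gave only a 1.4-fold higher number from compound 2 to compound 1 (0.15 log units; within the scatter), a small step is expected in this assay from compound 3 to compound 4 as well, estimated at a 1.0-fold lower number from compound 3 to compound 4 (0.02 log units; within the scatter). On that basis compound 4 is expected to give about 250000 nM in this assay, estimated to lie between 90000 nM and 700000 nM.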

Compound 4, inhibition constant: 133000 nM
Compound 4: middle estimate off by 1.9-fold (0.27 log units), on the high side; measured number inside the range.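

In this assay, the new step is a 2.0-fold lower number from compound 3 to compound 4 (0.29 log units; within the scatter), so swapping ethyl for isopropyl on this core, like adding the methyl on the triple-bonded carbon on the other core, gives a step that stays within the scatter when read alone. Set side by side, however, the two steps do not match: the same change on two cores in this assay, a 1.4-fold higher number (0.15 log units; within the scatter) from compound 2 to compound 1 and a 2.0-fold lower number (0.29 log units; within the scatter) from compound 3 to compound 4, 2.8-fold (0.45 log units) apart, beyond the scatter of two such steps This shows that in these two pairs the added methyl left each number close to that of its parent, but not that a step of one fixed size carries from one core to the other, and with the methyl entering on a triple-bonded carbon in one pair and on a saturated chain carbon bound to an amine nitrogen and a saturated chain carbon in the other, the effect of the core cannot be separated from that of the place.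

The compounds shown leave open what the same methyl would do at one and the same place on both cores, for instance with an isopropyl group on the amine of the core of compound 1. They also leave open how a longer chain or a cyclopropyl group on the amine of compound 3 would read in this assay.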